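Moving the fluorine on the aryl ring of compound 3

The source may hold more compounds than are shown below. What is called first, only, known or untested is meant among the compounds shown, and "the series" means these compounds.

Compound 1 `COc1cc(C2=NN(C(C)=O)C(c3cc(Cl)cc(Cl)c3)O2)cc(OC)c1OC`: 0%
Compound 2 `COc1cc(C2=NN(C(C)=O)C(c3cccc(OC)c3OC)O2)cc(OC)c1OC`: 3.8%
Compound 3 `COc1cc(C2=NN(C(C)=O)C(c3ccccc3F)O2)cc(OC)c1OC`: 29.6%

In a functional assay on BGC-823 cells (Homo sapiens) for antiproliferative activity, read by MTT assay, tested at 1 uM (on this read-out lower numbers stand for a weaker effect and higher numbers for a stronger effect at the one concentration tested), compound 3 stands highest of the three numbers measured; the nearest is compound 2, and the step of a number 25.8 percentage points higher from compound 2 to compound 3 (beyond the scatter) lies beyond the scatter, as does the step of a number 29.6 percentage points higher from compound 1 to compound 3 (beyond the scatter). The step of a number 3.8 percentage points higher from compound 1 to compound 2 (within the scatter) is within the scatter.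

Compound 4 `COc1cc(C2=NN(C(C)=O)C(c3cccc(F)c3)O2)cc(OC)c1OC` differs from compound 3 in one place: 3-fluorophenyl in place of 2-fluorophenyl on a saturated ring carbon

Within the data shown here, no measured step moves a single fluorine on the aryl ring; the steps seen so far exchange whole aryl groups and range from within the scatter up to a modest size. Compound 3 stands alone at the top, and the two other aryl groups sit far lower, so the change to compound 4 is estimated to cost some of that effect without any firm guide. The step of a number 11.6 percentage points lower from compound 3 to compound 4 (beyond the scatter) is therefore expected to be a modest decrease, possibly within the scatter. Compound 4 is expected to give 18%, with a range from 2% to 38%.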

Compound 4, a percentage reported as inhibition, at one concentration (the size of the read-out at that concentration, not a potency): 14.7%
Compound 4: the middle estimate sits 3.3 percentage points above what was measured; the range from low to high includes it.
By their numbers in this assay, from the lowest: compounds 1 and 2 (each within the scatter of the next); then compound 4; then compound 3.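

In this assay, where the fluorine sits on the aryl ring matters on its own: the two groups have the same atoms, joined differently, yet 3-fluorophenyl in place of 2-fluorophenyl gives a number 14.9 percentage points lower from compound 3 to compound 4 (beyond the scatter). The lower of the two fluorophenyl compounds still stands apart from the other two aryl groups, with a number 10.9 percentage points higher from compound 2 to compound 4 (beyond the scatter) and a number 14.7 percentage points higher from compound 1 to compound 4 (beyond the scatter), so among these four compounds both fluorophenyl groups rank above the 2,3-dimethoxyphenyl and 3,5-dichlorophenyl groups. Nothing available explains why moving the fluorine changes the read-out.

The compounds shown leave open how a 4-fluorophenyl or a 2-chlorophenyl group would compare with 2-fluorophenyl on this saturated ring carbon. They also leave open whether this order would hold at other concentrations, as each number here comes from a single concentration and is not a potency.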